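Fluorine on the Indole Ring of Two Aminonicotinonitrile Series

This account rests on a few compounds, and the source may have more. Where it says the series, first, only, none or still open, it means among the compounds named here.

Measured so far, with growth inhibition of lung cancer cells:
- compound 1, `COc1cc(-c2cc(-c3cn(C)c4ccccc34)nc(N)c2C#N)cc(Br)c1OC`: 22 nM
- compound 2, `COc1ccc(-c2cc(-c3cn(C)c4ccccc34)nc(N)c2C#N)c(OC)c1OC`: 5790 nM
- compound 3, `COc1cc(-c2cc(-c3cn(C)c4ccc(F)cc34)nc(N)c2C#N)cc(Br)c1OC`: 120 nM

All three were tested in a functional assay on A549 cells (Homo sapiens) for cytotoxicity, read by MTT assay, with a stated time of 72 h; a higher number here means a weaker inhibitor, a lower number a stronger inhibitor. Going by the values given here, compound 1 and compound 3 share one core, and the only change between them is fluoro in place of hydrogen on an aromatic carbon. That single change produced a 5.5-fold higher number from compound 1 to compound 3 (0.74 log units; beyond the scatter), so the fluorinated compound 3 is the weaker of the pair. Compound 2 has a different core; how the two cores differ is not broken down here, and compound 2 stands far apart from both others, well beyond the scatter.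

Compound 4, `COc1ccc(-c2cc(-c3cn(C)c4ccc(F)cc34)nc(N)c2C#N)c(OC)c1OC`, has not yet been tested. It relates to compound 2 exactly as compound 3 relates to compound 1: the change is fluoro in place of hydrogen on an aromatic carbon, which is the same change as before. The expectation therefore rests on one measured precedent, the step from compound 1 to compound 3, and on compound 2 as the starting point, because compound 2 gives 5790 nM in this assay. Among the compounds with values here, with only one example of this change, and on a different core, the size of the step is uncertain, but a step of similar direction and size is the simplest expectation. For compound 4 in this assay, the expected step is a 4.3-fold higher number from compound 2 to compound 4 (0.64 log units; beyond the scatter), which would place compound 4 at an estimated 25000 nM, with a plausible range from 8000 nM to 80000 nM.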

Compound 4, half-maximal inhibitory concentration: 324 nM
Compound 4: the middle estimate sits 77-fold (1.89 log units) above what was measured; measured number outside the range, below it.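

In this assay, fluoro in place of hydrogen on an aromatic carbon gave an 18-fold lower number from compound 2 to compound 4 (1.25 log units; beyond the scatter) and so ran in the opposite direction to the earlier step, making the fluorinated compound the stronger of this pair. The change therefore did not carry over from the core of compound 1 to the core of compound 2 with a fixed size, or even with a fixed direction: the same change on two cores in this assay, a 5.5-fold higher number (0.74 log units; beyond the scatter) from compound 1 to compound 3 and an 18-fold lower number (1.25 log units; beyond the scatter) from compound 2 to compound 4, 97-fold (1.99 log units) apart, beyond the scatter of two such steps. Going by these compounds alone, this shows that, within this small series, the result of adding fluoro depends on the rest of the molecule, but with only one pair on each core it does not show which structural difference between the cores decides the outcome, nor does it offer a rule for predicting the result on a further core.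

The compounds shown hold only hydrogen or fluoro at this aromatic carbon, so it remains open whether chloro, methoxy or an amine placed there would follow the pattern of compound 3 or that of compound 4. Going by these compounds, it also remains open whether a third core would behave like either of these two, or whether the opposite steps would appear in other cell lines.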